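Unsaturated Tail on a Vanilloid Hydrazide Antagonist

This account rests on a few compounds, and the source may have more. Where it says the series, first, only, none or still open, it means among the compounds named here.

Compound 2 `CCCCCCCCCCCCCCCC(=O)N/N=C/c1ccc(O)c(OC)c1` gives 280 nM in an assay on HEK293 cells for antagonist activity at transient receptor potential cation channel subfamily V member 2 (Rattus norvegicus), read by fluorescence and calcium flux, with a stated time of 5 min (a higher number here means a weaker inhibitor, a lower number a stronger inhibitor), the lowest of the two numbers measured. Compound 1 `CCCCCCCC/C=C\CCCCCCCCSC[C@H](N)C(=O)NCc1ccc(O)c(OC)c1` gives 1900 nM in this assay, a gap from compound 2 that lies beyond the scatter of repeated measurements. For compound 3 `CCCCCC[C@@H](O)C/C=C\CCCCCCCCSCCC(=O)NCc1ccc(O)c(OC)c1` the reading in this assay is a limit rather than a number, > 10000 nM, and one of the three values sits at that limit (the limit of > 10000 nM in this assay, at which 1 of the 3 values shown sits).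

Compound 4 `CCCCCCCC/C=C\CCCCCCCC(=O)N/N=C/c1ccc(O)c(OC)c1` differs from compound 2 in one place: dec-1-en-1-yl in place of octyl on a saturated chain carbon, seven bonds along the chain from a carbonyl carbon. Going by the values given here, no pair of measured compounds isolates this change. Compounds 1 and 3 also carry a double bond in their long chains, but each differs from compound 2 in several further ways, so neither singles out what the double bond does. Compound 4 is therefore expected to sit close to compound 2, with a step of a 1.4-fold higher number from compound 2 to compound 4 (0.15 log units; within the scatter) that is expected to stay within the scatter or to weaken inhibition slightly. Compound 4 is estimated at 400 nM, between 150 nM and 1500 nM.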

Compound 4, half-maximal inhibitory concentration: 120 nM
Beside the measured number, compound 4's estimate is 3.3-fold (0.52 log units) above it, and the stated range ends above it.
By their numbers in this assay, from the lowest: compound 4; then compound 2; then compound 1. At a limit, above all of these: compound 3.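

In this assay, dec-1-en-1-yl in place of octyl on a saturated chain carbon, seven bonds along the chain from a carbonyl carbon, gives a 2.3-fold lower number from compound 2 to compound 4 (0.37 log units; beyond the scatter), which shows that this part of the chain tolerates the change and that inhibition grows stronger with it. Going by these compounds alone, the earlier compounds with a double bond in their long chains differ from compound 2 in several further ways, so this step is the first to isolate a change at this position. The change brings in both added carbons and a double bond, and nothing measured here gives a cause for the step.

The compounds shown leave open whether the step follows the double bond or the added carbons, a question that a saturated decyl group at this place would address. They also leave open whether a trans double bond or a longer chain would keep, extend or reverse the step.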